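A few compounds are considered here, and "the series" means these few. Any claim that something is new, unique, unknown or untested is made for them only; others in the source may bear on it.

Of the compounds shown here, three have been measured in an ADME assay on microsomes (Mus musculus) for metabolic stability; on this read-out lower numbers stand for slow clearance and higher numbers for fast clearance. Compound 1 (`CCc1cc(C(F)(F)F)c2cccc(OCc3c(Cl)ccc(S(=O)(=O)N4CCC[C@H]4C(=O)NC)c3Cl)c2n1`) gives 1280 mL/min/kg, and compound 2 (`Cc1cc(C(F)(F)F)c2cccc(OCc3c(Cl)ccc(S(=O)(=O)N4CCC[C@H]4CO)c3Cl)c2n1`) gives 1630 mL/min/kg. Compound 3 (`CNC(=O)[C@@H]1CCCN1S(=O)(=O)c1ccc(Cl)c(COc2cccc3c(-c4cncn4C)cc(C)nc23)c1Cl`) gives 117 mL/min/kg, the lowest of the three numbers and well beyond the usual scatter from both of the others.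

The next structure, compound 4 (`CNC(=O)[C@@H]1CCCN1S(=O)(=O)c1ccc(Cl)c(COc2cccc3c(-c4ccccn4)cc(C)nc23)c1Cl`), has pyridin-2-yl in place of 1-methyl-1H-imidazol-5-yl on an aromatic carbon. For the measured compounds named here, no measured pair shows this swap on its own, and compounds 1 and 2 differ from compound 3 in more than one place, so the size of the step is a judgement. A rise seems likelier than a fall, since compound 3 at 117 mL/min/kg already sits at the low end of what has been seen. The expected change is a moderate rise, a 2.6-fold higher number from compound 3 to compound 4 (0.41 log units; beyond the scatter), a little beyond the scatter but well short of the numbers for compounds 1 and 2. Compound 4 is estimated at 300 mL/min/kg, with an expected range of 120 mL/min/kg to 750 mL/min/kg.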

Compound 4, clearance: 733 mL/min/kg
The estimate for compound 4 lay 2.4-fold (0.39 log units) below the measured number; the measured number falls inside the stated range.
By their numbers in this assay, from the lowest: compound 3; then compounds 4, 1 and 2 (each within the scatter of the next, the first and the last beyond it).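

In this assay, for the compounds shown here, placing pyridin-2-yl in place of 1-methyl-1H-imidazol-5-yl on this aromatic carbon, opposite the ring nitrogen, gives a 6.3-fold higher number from compound 3 to compound 4 (0.80 log units; beyond the scatter), the first direct reading of a change at this position. The two groups carry the same number of heavy atoms and differ in ring size and hetero atom count, so this position responds to more than the number of heavy atoms in the group. No measurement here explains which difference between the two rings accounts for the step.

Still open, going by these compounds, is how a plain phenyl ring or a pyridin-3-yl group would read at this carbon, which could help separate the effect of ring size from that of the ring nitrogens. Also open, on these data alone, is whether a small amine there would fit the same trend.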